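Cytotoxicity limits across the pyridyloxy cyclohexyl series

This account rests on a few compounds, and the source may have more. Where it says the series, first, only, none or still open, it means among the compounds named here.

Measured compounds:
Compound 1 `CC(C)(C)C#Cc1cc(N(C(=O)[C@H]2CC[C@H](C)CC2)[C@H]2CC[C@@H](Oc3cccnc3)CC2)c(C(=O)O)s1` — in an ADME assay on MT4 cells (Homo sapiens) for cytotoxicity, with a stated time of 5 days (on this read-out lower numbers stand for higher toxicity in this test and higher numbers for lower toxicity in this test), compound 1 gives > 20000 nM, a limit of the assay.
Compound 2 `CC(C)(C)C#Cc1cc(N(C(=O)[C@H]2CC[C@H](C)CC2)[C@H]2CC[C@H](O)CC2)c(C(=O)O)s1` — compound 2 gives > 20000 nM, also a limit.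
Compound 3 `CC(C)(C)C#Cc1cc(N(C(=O)[C@H]2CC[C@H](C)CC2)[C@H]2CC[C@H](Oc3ccc(=O)[nH]n3)CC2)c(C(=O)O)s1` — compound 3 gives > 20000 nM, again a limit.

Compound 3 thus stands at the limit, as do the other two values shown, so the step that the two limits leave unreadable from compound 2 to compound 3 cannot be read. Compound 4 `CC(C)(C)C#Cc1cc(N(C(=O)[C@H]2CC[C@H](C)CC2)[C@H]2CC[C@H](Oc3cccnc3)CC2)c(C(=O)O)s1` differs from compound 3 by a group of 6 heavy atoms (5 carbon, 1 nitrogen; one six-membered aromatic ring with 1 hetero atom) in place of a group of 7 heavy atoms (4 carbon, 2 nitrogen, 1 oxygen; one six-membered aromatic ring with 2 hetero atoms), on an oxygen on a saturated carbon. Among the measured compounds shown here, no measured step bears on this change; the only guidance is the limit of > 20000 nM in this assay, at which 3 of the 3 values shown sit, where every value sits. In this assay no step beyond the scatter is expected, a number no higher from compound 3 to compound 4 (the limit leaves the size open). Compound 4 is estimated at 20000 nM, with a range from 10000 nM to 40000 nM, and is expected most likely to be reported again as a limit.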

Compound 4, half-maximal cytotoxic concentration: > 20000 nM
Compound 4 gave a limit, no number (the forecaster's own chance of this, stated with the estimate: 85%); the middle value sits exactly at the limit.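

In this assay compound 4 gives > 20000 nM, a limit and not a number, so no step to it from compounds 1, 2 or 3 can be read: the limit of > 20000 nM in this assay, at which 4 of the 4 values shown sit.

Left open is whether the group on the oxygen, or the configuration as drawn, changes this read-out at all: the fact that compounds 1 and 4 differ only in the configuration as drawn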